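The compounds below may be only part of what the source reports. "The series", "measured", "known", "first", "only" and "open" are said of these compounds alone.

Working notes on the series. Compound 1 `C#CC=C(c1cc(OC)cc(OC)c1)c1ccc(OC)c(OC)c1` carries an ethynyl group on a double-bonded chain carbon bound to a double-bonded chain carbon, and in a functional assay on HCT-116 cells (Homo sapiens) for cytotoxicity, read by scintillation counting and thymidine incorporation, with a stated time of 72 h (a higher number here means a weaker inhibitor, a lower number a stronger inhibitor), compound 1 gives only a limit of the assay, > 10000 nM. Compound 2 `COC(=O)C=C(c1cc(OC)cc(OC)c1)c1ccc(OC)c(OC)c1` carries methoxycarbonyl at the same place. In this assay compound 2 likewise gives only a limit, > 10000 nM. Going by the values given here, the one measured step, a step that the two limits leave unreadable from compound 1 to compound 2, is therefore not readable, since (the limit of > 10000 nM in this assay, at which 2 of the 2 values shown sit).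

Compound 3 `C=C(c1cc(OC)cc(OC)c1)c1ccc(OC)c(OC)c1` is the next member. It differs from compound 2 by hydrogen in place of methoxycarbonyl on a double-bonded chain carbon bound to a double-bonded chain carbon.

Among the compounds with values here, no measured step bears on this change beyond the unreadable one from compound 1 to compound 2, and both values so far sit at the limit, so nothing in the numbers points to a direction in this assay for compound 3. The expectation can only be held open. For compound 3 in this assay the value is estimated at 6000 nM, within a range of 500 nM to 60000 nM. The step from compound 2 to compound 3 that this expectation means, an at least 1.6-fold lower number from compound 2 to compound 3 (0.22 log units; that floor lies within the scatter), is an estimate without a measured anchor and may well again end at the limit.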

Compound 3, half-maximal inhibitory concentration: > 10000 nM
Compound 3 was reported as a limit; the forecaster's own chance of this, stated with the estimate: 50%; middle value at least 1.6-fold (0.22 log units) away from the limit.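

Compound 3 also gives only a limit in this assay, so the steps to it from compound 1 and from compound 2 cannot be read: the limit of > 10000 nM in this assay, at which 3 of the 3 values shown sit. The compounds shown leave open how ethynyl, methoxycarbonyl and hydrogen rank against one another at this place on the shared core, as all three remain unresolved in this assay here.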